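Methoxy in Place of Bromo on the Shared Core

A few compounds are considered here, and "the series" means these few. Any claim that something is new, unique, unknown or untested is made for them only; others in the source may bear on it.

Measured compounds:
Compound 1, `Nc1scc(-c2ccc(Cl)cc2)c1C(=O)c1ccccc1`, gives 51% in a functional assay on CHO cells for agonist activity at adenosine receptor A1 (Homo sapiens), read by fluorescence and ERK phosphorylation, with stated times of 30 min and 1.5 h, tested at 10 uM; a lower number here means a weaker effect, a higher number a stronger effect of the compound at the concentration tested.
Compound 2, `Nc1scc(-c2ccc(Br)cc2)c1C(=O)c1ccccc1`, gives 49% in this assay.

Compound 2 has the lowest of the two numbers, yet its nearest neighbour is compound 1, and the step of a number 2 percentage points lower from compound 1 to compound 2 (within the scatter) is within the scatter, so the two compounds cannot be told apart on this read-out. The change now followed is methoxy in place of bromo on an aromatic carbon, giving compound 3, `COc1ccc(-c2csc(N)c2C(=O)c2ccccc2)cc1`. For the measured compounds named here, the only measured step, from compound 1 to compound 2, swaps one halogen for another on that same aromatic carbon and hardly moves the number. Going by the values given here, no measured step exchanges a halogen for methoxy, so that step is a guess supported only by the flat behaviour seen so far. Compound 3 is therefore expected to stay close to its neighbours, with a step of about a number 4 percentage points lower from compound 2 to compound 3 (within the scatter), and its estimated value is 45%, within a range from 25% to 65%.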

Compound 3, a percentage reported as activity, at one concentration (the size of the read-out at that concentration, not a potency): 52%
Compound 3: middle estimate off by 7 percentage points, on the low side, and the stated range covers the measured number.
By their numbers in this assay, from the lowest: compounds 2, 1 and 3 (each within the scatter of the next).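

For the compounds shown here, on this aromatic carbon, para to a large group, the earlier compounds showed only one halogen exchanged for another. Methoxy is a different kind of group, with carbon and oxygen in place of a single bromine and with a hydrogen-bond acceptor that bromo lacks, yet this assay shows a number 3 percentage points higher from compound 2 to compound 3 (within the scatter) and a number 1 percentage points higher from compound 1 to compound 3 (within the scatter) and so cannot tell chloro, bromo and methoxy apart at this position. No evidence is available that would explain this flat result.

Going by these compounds, it remains open whether an amine, a carboxylic acid or a longer chain such as butoxy at this position would move the number beyond the scatter. The compounds shown also leave open how changes elsewhere on the shared core would read in this assay.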